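Amide swap on an oxadiazole-azetidine series

The source may report more compounds than this note shows. Statements on the series, on what has been measured and on what is new or still open speak of the compounds shown alone.

Measured so far:
compound 1, `O=C(C1CCC(F)(F)CC1)N1CC(c2nc(-c3cccc(F)c3)no2)C1` — > 10000 nM in an assay on HEK293 cells for negative allosteric modulation of metabotropic glutamate receptor 5 (Homo sapiens), read by FLIPR; a lower number here means a stronger inhibitor, a higher number a weaker inhibitor
compound 2, `Cc1cccc(-c2noc(C3CN(C(=O)c4ccccc4F)C3)n2)c1` — 1400 nM

Compound 1 sits at the limit of this assay with > 10000 nM, a limit rather than a number. Among the measured compounds shown here, compound 2 is the only compound with a numeric value in this assay, giving 1400 nM. The other entry belongs to compound 1 and is the limit of > 10000 nM in this assay, at which 1 of the 2 values shown sits. For the measured compounds named here, compound 1 and compound 2 differ in two places, so no single step between them is counted.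

Compound 3, `Cc1cccc(-c2noc(C3CN(C(=O)C4CCC(F)(F)CC4)C3)n2)c1`, is yet to be measured. It differs from compound 2 by 4,4-difluorocyclohexyl in place of 2-fluorophenyl on a carbonyl carbon. Going by the values given here, the amide carried by compound 3 is the one also present in compound 1, which reached only its limit; the oxadiazole substituent is that of compound 2. Since compound 1 gave > 10000 nM, the expectation is a loss of potency, moving compound 3 toward or onto the limit. For compound 3 the estimate is 5000 nM (range 1500 nM to 20000 nM), an expected step of a 3.6-fold higher number from compound 2 to compound 3 (0.55 log units; beyond the scatter).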

Compound 3, half-maximal inhibitory concentration: > 10000 nM
Compound 3: only a limit was reported; the forecaster's own chance of this, stated with the estimate: 40%; middle value at least 2.0-fold (0.30 log units) away from the limit.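

In this assay, among the compounds shown here, 4,4-difluorocyclohexyl in place of 2-fluorophenyl on a carbonyl carbon gives an at least 7.1-fold higher number from compound 2 to compound 3 (0.85 log units; beyond the scatter), the first single-change reading at this position. For the compounds shown here, compound 3 gives > 10000 nM, a limit and not a number, so 2-fluorophenyl remains the only amide group here with a numeric value. The step from compound 1 to compound 3, methyl in place of fluoro on an aromatic carbon, cannot be read, since both values are limits: the limit of > 10000 nM in this assay, at which 2 of the 3 values shown sit.

Still open, as far as these compounds go, is whether the 2-fluorophenyl amide keeps a numeric value when fluoro replaces methyl on that aromatic carbon. A plain phenyl or an unsubstituted cyclohexyl on the same carbonyl carbon would help separate the change of ring from the change in fluorine.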